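This account rests on a few compounds, and the source may have more. Where it says the series, first, only, none or still open, it means among the compounds named here.

Compound 3 `O=C(O)CC(O)(CSCCCCCCc1ccc(F)cc1)C(=O)O` carries the same core as compound 1 `O=C(O)CC(O)(CSCCCCCCc1cccc(Cl)c1)C(=O)O`, with a 4-fluorophenyl group at the end of the chain. In an assay on isolated protein for inhibition of ATP-citrate synthase (Rattus norvegicus) (a lower number here means a stronger inhibitor, a higher number a weaker inhibitor), compound 3 gives 120000 nM, the second highest of the three numbers. Compound 1 gives 150000 nM, and the step of a 1.3-fold lower number from compound 1 to compound 3 (0.10 log units; within the scatter). Compound 2 `O=C(O)CC(O)(CSCCCCCCc1cccc(Cl)c1Cl)C(=O)O` gives 7300 nM, so that a 16-fold higher number from compound 2 to compound 3 (1.22 log units; beyond the scatter). Compound 4 `O=C(O)CC(O)(CSCCCCCCc1ccc(C(=O)O)cc1)C(=O)O` differs from compound 3 by carboxy in place of fluoro on an aromatic carbon. Among the compounds with values here, no measured step exchanges a fluoro for a carboxy group. The steps that touch the aromatic ring are a 21-fold lower number from compound 1 to compound 2 (1.31 log units; beyond the scatter), a large one, and a 1.3-fold lower number from compound 1 to compound 3 (0.10 log units; within the scatter), which stays within the scatter; neither involves a carboxy group, so the data give no direct guide for this change. The account therefore expects for compound 4 a step of a 1.2-fold lower number from compound 3 to compound 4 (0.08 log units; within the scatter), that is, no clear movement beyond the scatter. Compound 4 is estimated at 100000 nM, with a range from 25000 nM to 400000 nM.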

Compound 4, inhibition constant: 420000 nM
Estimate against measurement, compound 4: 4.2-fold (0.62 log units) below; the whole stated range lies below it.
By their numbers in this assay, from the lowest: compound 2; then compounds 3 and 1 (each within the scatter of the next); then compound 4.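

Carboxy in place of fluoro on an aromatic carbon, para to a large group, brings a 3.5-fold higher number from compound 3 to compound 4 (0.54 log units; beyond the scatter) in this assay. This shows that the group at this position can move the number beyond the scatter, and here the move is towards weaker inhibition, the opposite direction to the large gain seen in a 21-fold lower number from compound 1 to compound 2 (1.31 log units; beyond the scatter), where a chloro group enters the ring. Nothing at hand explains the change at this position.

On these data alone, a single step cannot separate what belongs to the carboxy group from what any larger group at this place might do, so it remains open whether an amide or a methyl ester would give a similar number. Also open, as far as these compounds go, is whether a second chloro group on the ring of compound 4 would bring the gain seen with compound 2.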